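This account rests on a few compounds, and the source may have more. Where it says the series, first, only, none or still open, it means among the compounds named here.

Compound 2 `CC(=O)N1c2ccccc2CCC1C(=O)Nc1ccccc1C(F)(F)F` stands only at a limit. In a functional assay on ACHN cells (Homo sapiens) for cytotoxicity, read by sulforhodamine B assay, with a stated time of 72 h (a lower number here means a stronger inhibitor of growth, a higher number a weaker inhibitor of growth), compound 2 gives > 80000 nM, a limit of the assay rather than a number (the limit of > 80000 nM in this assay, at which 1 of the 2 values shown sits). Compound 1 `CCCC(=O)N1c2ccccc2CCC1C(=O)Nc1ccccc1C(F)(F)F` likewise stands at a limit: in this assay compound 1 gives > 70000 nM (the limit of > 70000 nM in this assay, at which 1 of the 2 values shown sits). The step that the two limits leave unreadable from compound 1 to compound 2 is unreadable between these two limits. Compound 3 `O=C(Nc1ccccc1C(F)(F)F)C1CCc2ccccc2N1C(=O)c1ccccc1Cl` differs from compound 2 by 2-chlorophenyl in place of methyl on a carbonyl carbon. Within the data shown here, no measured step bears on this change, and both measured values are limits, so neither size nor direction can be read. Compound 3 is expected at 70000 nM (range 20000 nM to 200000 nM). The expected step is an at least 1.1-fold lower number from compound 2 to compound 3 (0.05 log units; that floor lies within the scatter).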

Compound 3, concentration for 50% growth inhibition: 3900 nM
Estimate against measurement, compound 3: 18-fold (1.25 log units) above, outside the stated range (below it).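

On the carbonyl carbon bound to the amide-type nitrogen in a ring, 2-chlorophenyl gives the only readable growth inhibition among the compounds shown in this assay (an at least 20-fold lower number from compound 2 to compound 3 (1.31 log units; beyond the scatter); an at least 17-fold lower number from compound 1 to compound 3 (1.25 log units; beyond the scatter)). Both steps are floors, since the values of compound 1 and compound 2 are limits of the assay and not numbers. Nothing shown gives a cause for this gain.

Going by these compounds, whether it depends on the chlorine or on the aromatic ring stays open. So does the outcome with phenyl, 2-methoxyphenyl or cyclohexyl on this carbonyl.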